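Swapping the ring-bound amine substituent of compound 3

The source may hold more compounds than are shown below. What is called first, only, known or untested is meant among the compounds shown, and "the series" means these compounds.

Compound 3 `CC(=O)c1cnc(N2CCC(c3coc4c(N5CCc6cc(S(C)(=O)=O)ccc65)ncnc34)CC2)nc1` gives 12% in a functional assay on cells for agonist activity at Glucose-dependent insulinotropic receptor (Homo sapiens), read by a luciferase reporter, with a stated time of 4 h (a higher number here means a larger maximal response, a lower number a smaller maximal response), the lowest of the three numbers measured. Compound 1 `Cc1cnc(N2CCC(c3coc4c(N5CCc6cc(S(C)(=O)=O)ccc65)ncnc34)CC2)nc1` gives 159% and compound 2 `CS(=O)(=O)c1ccc2c(c1)CCN2c1ncnc2c(C3CCN(c4ncccn4)CC3)coc12` gives 196%. The two steps that lead to compound 3 are large: a number 147 percentage points lower from compound 1 to compound 3 (beyond the scatter) and a number 184 percentage points lower from compound 2 to compound 3 (beyond the scatter), both as acetyl enters on an aromatic carbon. Compound 4 `CC(C)(C)OC(=O)N1CCC(c2coc3c(N4CCc5cc(S(C)(=O)=O)ccc54)ncnc23)CC1` is the next change: tert-butoxycarbonyl in place of 5-acetylpyrimidin-2-yl on an amine nitrogen in a ring. The whole 5-acetylpyrimidin-2-yl group, acetyl included, leaves the amine nitrogen in the ring. For the measured compounds named here, since the acetyl coincided with the steep drop, its removal is expected to lift the response, but no measured step shows tert-butoxycarbonyl here. For compound 4 the expected step is a number 108 percentage points higher from compound 3 to compound 4 (beyond the scatter), giving an estimate of 120%, within 40% to 200%.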

Compound 4, largest response reached (Emax), in percent of the reference or control that the assay uses: 123%
The estimate for compound 4 lay 3 percentage points below the measured number; the measured number falls inside the stated range.
By their numbers in this assay, from the lowest: compound 3; then compound 4; then compound 1; then compound 2.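

On the amine nitrogen in the ring, a group without any aromatic ring still gives a large response in this assay, with a number 111 percentage points higher from compound 3 to compound 4 (beyond the scatter) as tert-butoxycarbonyl replaces 5-acetylpyrimidin-2-yl. A pyrimidine is therefore not needed at this position for a response. Tert-butoxycarbonyl still falls short of the other two pyrimidines, with a number 73 percentage points lower from compound 2 to compound 4 (beyond the scatter) and a number 36 percentage points lower from compound 1 to compound 4 (beyond the scatter).

Nothing available explains these differences. Open, from the compounds shown here alone, is how this nitrogen behaves with only hydrogen on it, or with a plain ethyl chain or a benzyl group.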